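This account rests on a few compounds, and the source may have more. Where it says the series, first, only, none or still open, it means among the compounds named here.

- Compound 1 `Cc1cccc(C[C@H]2C(=O)OC[C@@H]2Cc2ccccc2)c1`: 53000 nM
- Compound 2 `O=C1OC[C@H](Cc2ccccc2)[C@H]1Cc1cccc(F)c1`: 75000 nM
- Compound 3 `O=C1OC[C@H](Cc2ccccc2)[C@H]1Cc1ccc(OC(F)(F)F)cc1`: 27000 nM
- Compound 4 `O=C1OC[C@H](Cc2ccccc2)[C@H]1Cc1ccc(F)cc1`: not yet measured

In a functional assay on HL-60 cells (Homo sapiens) for cytotoxicity, read by WST assay, with a stated time of 48 h (on this read-out higher numbers stand for an effect only at larger amounts of compound and lower numbers for an effect already at smaller amounts), compound 3 gives 27000 nM. Compound 1 gives 53000 nM, which is within the scatter of that number. Compound 2 gives 75000 nM, and compound 3 lies clearly lower, beyond the scatter. Compound 4 puts fluoro in place of trifluoromethoxy on an aromatic carbon. Among the compounds with values here, no measured step makes this exact swap. The nearest is a 1.4-fold higher number from compound 1 to compound 2 (0.15 log units; within the scatter), a fluoro in place of methyl, which stays within the scatter. Compound 2, which also carries a fluoro, stands at 75000 nM, so a modest rise is expected rather than a large one. The expected change is a 1.9-fold higher number from compound 3 to compound 4 (0.27 log units; within the scatter). For compound 4 the estimated value is 50000 nM, with an expected range of 24000 nM to 100000 nM.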

Compound 4, half-maximal effective concentration: 57000 nM
Compound 4: the middle estimate sits 1.1-fold (0.06 log units) below what was measured; the measured number falls inside the stated range.
By their numbers in this assay, from the lowest: compounds 3, 1, 4 and 2 (each within the scatter of the next, the first and the last beyond it).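

Fluoro in place of trifluoromethoxy on this aromatic carbon in this assay brings a 2.1-fold higher number from compound 3 to compound 4 (0.32 log units; beyond the scatter) and so is a modest change at this position that lies beyond the scatter. By contrast, 4-fluorophenyl in place of 3-fluorophenyl brings a 1.3-fold lower number from compound 2 to compound 4 (0.12 log units; within the scatter) and 4-fluorophenyl in place of 3-methylphenyl brings a 1.1-fold higher number from compound 1 to compound 4 (0.03 log units; within the scatter) and neither step can be told apart from the scatter. No measurement on hand offers a reason for the step away from trifluoromethoxy.

As far as these compounds go, whether an amine, a carboxylic acid or a longer chain on this aromatic carbon would move the number further remains open.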